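The source may report more compounds than this note shows. Statements on the series, on what has been measured and on what is new or still open speak of the compounds shown alone.

Of the compounds shown here, two built on the shared core have been measured in a functional assay on MGC-803 cells (Homo sapiens) for inhibition, read by sulforhodamine B assay; on this read-out lower numbers stand for stronger inhibition and higher numbers for weaker inhibition. Within the data shown here, compound 1 `CCCc1ccc(NC2=CC(=O)c3nc4n(c3C2=O)[C@H]2OC[C@@H](O)[C@H]2OC4)cc1` gives 1560 nM in this assay, which is the lowest of the two numbers so far. Compound 2 `COc1ccc(NC2=CC(=O)c3c(nc4n3[C@H]3OC[C@@H](O)[C@H]3OC4)C2=O)cc1` gives 2150 nM in this assay; the gap between compound 1 and compound 2 is within the scatter, so the two stand together and no order between them can be read. Among the measured compounds shown here, no step between measured compounds that differ in one place is available, so the size of single changes is not yet known.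

Compound 3 `COc1cccc(NC2=CC(=O)c3nc4n(c3C2=O)[C@H]2OC[C@@H](O)[C@H]2OC4)c1` remains to be measured in this assay. It differs from compound 1 as follows: 3-methoxyphenyl in place of 4-propylphenyl on an amine nitrogen. The step from compound 1 to compound 3 is expected to be a 1.4-fold higher number from compound 1 to compound 3 (0.15 log units; within the scatter), a small move toward weaker inhibition that stays within the scatter, because compound 2 gives 2150 nM in this assay and is close in build to compound 3. Compound 3 is therefore estimated at 2200 nM, with a range from 1000 nM to 5000 nM.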

Compound 3, half-maximal inhibitory concentration: 1780 nM
Compound 3: the middle estimate sits 1.2-fold (0.09 log units) above what was measured; the range from low to high includes it.
By their numbers in this assay, from the lowest: compounds 1, 3 and 2 (each within the scatter of the next).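

Among these compounds, compound 3 gives the first step with a single change, on an amine nitrogen whose other neighbour is a double-bonded ring carbon: in this assay, 3-methoxyphenyl in place of 4-propylphenyl gives a 1.1-fold higher number from compound 1 to compound 3 (0.06 log units; within the scatter). This step lies within the scatter, so this exchange of aryl groups, which replaces an all-carbon group with one carrying a hydrogen-bond acceptor, leaves no readable change in inhibition of MGC-803 cells. Nothing measured here accounts for this result, and the step alone gives no reason for it.

The compounds shown leave open whether any group at this position can move the number beyond the scatter, for example a phenyl ring bearing a carboxylic acid, an amine or a nitrile, or one with a chain longer than propyl. Also open is how far the number depends on the shared core itself, such as when an amine stands in place of its hydroxyl, since all the compounds shown keep that part unchanged.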